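The compounds below may be only part of what the source reports. "The series", "measured", "known", "first", "only" and "open" are said of these compounds alone.

Measured compounds:
- compound 1, `CCOC(=O)C1CCN(C(=O)CN2CN(c3ccccc3)C3(CCN(C(=O)c4ccc(C5CCCCC5)cc4)CC3)C2=O)CC1`: 900 nM
- compound 2, `CC(C)(C)c1ccc(C(=O)N2CCC3(CC2)C(=O)N(CC(=O)N2CCCCC2CCO)CN3c2ccccc2)cc1`: 6100 nM
- compound 3, `CC(C)(C)c1ccc(C(=O)N2CCC3(CC2)C(=O)N(CC(=O)NCCCN)CN3c2ccccc2)cc1`: 4200 nM

In an assay on HEK293 cells for displacement of a labelled ligand from NPC1-like intracellular cholesterol transporter 1 (Homo sapiens) (a lower number here means a stronger inhibitor, a higher number a weaker inhibitor), compound 1 gives 900 nM, the lowest of the three numbers; its gaps to compound 3 and to compound 2 both lie beyond the usual scatter. Compound 4, `O=C(CN1CN(c2ccccc2)C2(CCN(C(=O)c3ccc(C4CCCCC4)cc3)CC2)C1=O)NCCO`, differs from compound 1 at one place: (2-hydroxyethyl)amino in place of 4-(ethoxycarbonyl)piperidin-1-yl on a carbonyl carbon. One measured step resembles this kind of change, a ring-bound amide nitrogen giving way to an open-chain amino group on the same carbonyl carbon: a 1.5-fold lower number from compound 2 to compound 3 (0.16 log units; within the scatter). That step stayed within the scatter, so for compound 4 a change of similar small size is expected, no change at the digits printed from compound 1 to compound 4 (within the scatter), not clearly in either direction. Compound 4 is therefore estimated at 900 nM, with a range from 300 nM to 2700 nM.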

Compound 4, half-maximal inhibitory concentration: 2000 nM
Estimate against measurement, compound 4: 2.2-fold (0.35 log units) below; low and high end bracket the measured number.
By their numbers in this assay, from the lowest: compound 1; then compound 4; then compounds 3 and 2 (each within the scatter of the next).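

In this assay, putting (2-hydroxyethyl)amino in place of 4-(ethoxycarbonyl)piperidin-1-yl on this carbonyl carbon gives a 2.2-fold higher number from compound 1 to compound 4 (0.35 log units; beyond the scatter) and so moves the number beyond the scatter, which the earlier step at such a carbonyl carbon did not do. This change therefore registers in the series containing compound 1, although the rise is modest. Nothing measured here explains the rise.

The change removes the ring and the ester together, so the compounds shown leave open which of the two matters. A plain piperidin-1-yl, a piperidine carrying a carboxylic acid, or a longer (3-hydroxypropyl)amino chain at this place would help separate them.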